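Bromo to Fluoro on a Shared Aromatic Ring

This account rests on a few compounds, and the source may have more. Where it says the series, first, only, none or still open, it means among the compounds named here.

Measured compounds:
Compound 1, `COC(=O)[C@@]1(C)C[C@@H](c2coc3ccc(Br)cc3c2=O)N(c2ccccc2)O1`, gives 14700 nM in a functional assay on THP-1 cells (Homo sapiens) for inhibition, read by sulforhodamine B assay, with a stated time of 48 h; a lower number here means a stronger inhibitor, a higher number a weaker inhibitor.
Compound 2, `O=C1[C@H]2[C@H](ON(c3ccccc3)[C@@H]2c2coc3ccc(F)cc3c2=O)C(=O)N1c1ccccc1`, gives 43500 nM in this assay.
Compound 3, `O=C1[C@H]2[C@H](ON(c3ccccc3)[C@@H]2c2coc3ccc(Br)cc3c2=O)C(=O)N1c1ccccc1`, gives 22300 nM in this assay.

Compounds 2 and 3 share one core and differ in a single place: fluoro in place of bromo on an aromatic carbon. That change produced a 2.0-fold higher number from compound 3 to compound 2 (0.29 log units; within the scatter). Compound 1 is built on a different core, and how its core differs from that of compound 3 is not broken down here. Compound 1 carries the lowest number of the three, but its gap to compound 3 lies within the scatter, so no order between those two can be claimed; only compound 2 stands beyond the scatter from compound 1.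

Compound 4, `COC(=O)[C@@]1(C)C[C@@H](c2coc3ccc(F)cc3c2=O)N(c2ccccc2)O1`, has not yet been measured. It differs from compound 1 by fluoro in place of bromo on an aromatic carbon, the same change as from compound 3 to compound 2, made at the same place. In this assay the step from compound 1 to compound 4 is expected to be a 2.0-fold higher number from compound 1 to compound 4 (0.30 log units; within the scatter) because the same change earlier gave a 2.0-fold higher number from compound 3 to compound 2 (0.29 log units; within the scatter). Compound 4 is therefore estimated at 29000 nM, with a likely range from 12000 nM to 70000 nM.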

Compound 4, half-maximal inhibitory concentration: 47000 nM
Compound 4: the middle estimate sits 1.6-fold (0.21 log units) below what was measured; low and high end bracket the measured number.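

In this assay, putting fluoro in place of bromo on the core of compound 1 gave a 3.2-fold higher number from compound 1 to compound 4 (0.50 log units; beyond the scatter), so the number rose on this core as it did on the core of compound 3. Set side by side, the two steps cannot be told apart, which means that in this series the change carried from one core to the other with no measurable difference in its size: the same change on two cores in this assay, a 2.0-fold higher number (0.29 log units; within the scatter) from compound 3 to compound 2 and a 3.2-fold higher number (0.50 log units; beyond the scatter) from compound 1 to compound 4, 1.6-fold (0.21 log units) apart, within the scatter of two such steps. Among these compounds, this rests on only two pairs of compounds, and only the new step stands clear of the scatter by itself, so it shows neither that the change would behave alike on a third core nor why the number rises.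

The compounds shown leave open what other groups would do on the same aromatic carbon, such as chloro, methyl, methoxy or a nitrile. They also leave open whether changing the methyl ester of compound 1 to a carboxylic acid or an amide would alter the outcome of the bromo to fluoro change.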